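The source may hold more compounds than are shown below. What is called first, only, known or untested is meant among the compounds shown, and "the series" means these compounds.

Measured so far in an assay (strain Wistar) for binding affinity to Neuronal acetylcholine receptor; alpha4/beta2 (Rattus norvegicus); a higher number here means a weaker inhibitor, a lower number a stronger inhibitor:
compound 1 `COc1cc(N2CCNCC2)cnc1Br` gives 180 nM;
compound 2 `Clc1cncc(N2C3CCCC2CNCC3)c1` gives 8.4 nM;
compound 3 `COc1cncc(N2CCCNCCC2)c1` gives 1 nM.

Compound 3 stands at the lowest number of the three, and its gaps to compound 2 and to compound 1 both lie beyond the scatter, so on these numbers compound 3 is the strongest inhibitor of the set. Compound 4 `Brc1cncc(N2CCCNCCC2)c1` is not yet measured. It differs from compound 3 in one place: bromo in place of methoxy on an aromatic carbon. Within the data shown here, no step between measured compounds shows this exchange alone, so the data do not fix its size. Compound 1 also carries a bromo, but alongside a methoxy and on a different core, so its value says nothing about this exchange by itself. In this assay the step of a 3.0-fold higher number from compound 3 to compound 4 (0.48 log units; beyond the scatter) is expected to be modest and upward, within or just beyond the scatter. Compound 4 is estimated at 3 nM, with a range from 0.5 nM to 15 nM.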

Compound 4, half-maximal inhibitory concentration: 2.8 nM
Compound 4: middle estimate off by 1.1-fold (0.03 log units), on the high side; low and high end bracket the measured number.
By their numbers in this assay, from the lowest: compound 3; then compound 4; then compound 2; then compound 1.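

In this assay, among these compounds, bromo in place of methoxy on this aromatic carbon, two atoms from the ring nitrogen, gives a 2.8-fold higher number from compound 3 to compound 4 (0.45 log units; beyond the scatter), the first direct reading of this exchange on the shared core. The step is modest but beyond the scatter, so this position accepts either group, with methoxy giving the lower number. No available measurement accounts for the step.

Open, going by these compounds, is how an amine or a nitrile would read at this carbon. Also open, on these data alone, is whether the exchange keeps this size on the core of compound 2.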